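Swapping the Aryl Group on an Ester of a Shared Core

The source may report more compounds than this note shows. Statements on the series, on what has been measured and on what is new or still open speak of the compounds shown alone.

Compound 1 `C/C(=C\CC/C(C)=C/CC[C@@H]1[C@@]2(C)CCC(=O)C(C)(C)[C@H]2CC[C@@]1(C)O)CC/C=C(\C)C(=O)OCc1cn(-c2ccc([N+](=O)[O-])cc2)nn1`: > 150000 nM in a functional assay on DU-145 cells (Homo sapiens) for antiproliferative activity, read by MTT assay, with a stated time of 48 h (a higher number here means a weaker inhibitor, a lower number a stronger inhibitor), which is a limit of the assay, not a number.
Compound 2 `C/C(=C\CC/C(C)=C/CC[C@@H]1[C@@]2(C)CCC(=O)C(C)(C)[C@H]2CC[C@@]1(C)O)CC/C=C(\C)C(=O)OCc1cn(-c2ccccc2Br)nn1`: > 150000 nM in this assay, again a limit of the assay.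
Compound 3 `C#CCOC(=O)/C(C)=C/CC/C(C)=C/CC/C(C)=C/CC[C@@H]1[C@@]2(C)CCC(=O)C(C)(C)[C@H]2CC[C@@]1(C)O`: 46100 nM in this assay.

Compound 1 therefore stands only at a limit, and (the limit of > 150000 nM in this assay, at which 2 of the 3 values shown sit). Compound 4 `C/C(=C\CC/C(C)=C/CC[C@@H]1[C@@]2(C)CCC(=O)C(C)(C)[C@H]2CC[C@@]1(C)O)CC/C=C(\C)C(=O)OCc1cn(-c2ccccc2C)nn1` differs from compound 1 by 2-methylphenyl in place of 4-nitrophenyl on an aromatic nitrogen. For the measured compounds named here, two measured steps bear on this change. The step that the two limits leave unreadable from compound 1 to compound 2 is also a swap of one aryl group for another on the same aromatic nitrogen, and its size cannot be read because both ends sit at the limit. The step of an at least 3.2-fold lower number from compound 2 to compound 3 (0.51 log units; beyond the scatter) shows that a readable number appears only once the 1-(2-bromophenyl)-1H-1,2,3-triazol-4-yl group is replaced by ethynyl. Since compound 4 keeps that group type and changes only the aryl part, the expected step is a number no higher from compound 1 to compound 4 (the limit leaves the size open), meaning no movement beyond the scatter. Compound 4 is estimated at 150000 nM, with a likely range from 60000 nM to 400000 nM.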

Compound 4, half-maximal inhibitory concentration: > 150000 nM
Compound 4: no number, only a limit (the forecaster's own chance of this, stated with the estimate: 70%); the middle value lies on the limit itself.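

Compound 4 shows that a third aryl group on this aromatic nitrogen, 2-methylphenyl, built of carbon only, also gives no readable number in this assay, and its result is a limit of the assay, the same one reached with 4-nitrophenyl and 2-bromophenyl: the limit of > 150000 nM in this assay, at which 3 of the 4 values shown sit.

The steps among compound 1, compound 2 and compound 4 cannot be read, as both ends of each sit at that limit. For the compounds shown here, the one readable comparison is an at least 3.2-fold higher number from compound 3 to compound 4 (0.51 log units; beyond the scatter), so the aryl triazole with a methyl group sits on the weaker side of the ethynyl ester, as the one with bromo does.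

From the compounds shown here alone, how far these three compounds lie past the limit stays unknown, so their aryl groups cannot be ranked. Also open, going by these compounds, is whether an amine or a carboxylic acid on the phenyl ring, or a plain alkyl chain in its place, would bring a readable number.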